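The compounds below may be only part of what the source reports. "The series", "measured", "known", "first", "only" and "open" are said of these compounds alone.

In an ADME assay on a cell-free system (plasma, Homo sapiens) for metabolic stability, tested at 1 uM (a lower number here means that the compound disappears faster, a higher number that the compound lasts longer), compound 1 `C=CC(=O)NCC1CCN(S(=O)(=O)c2ccc(NC(=O)OCc3ccccc3)cc2)CC1` gives > 6 h, which is a limit of the assay and not a number. Compound 2 `C=CC(=O)N[C@H]1CCCN(S(=O)(=O)c2ccc(NC(=O)OCc3ccccc3)cc2)C1` gives > 6 h, and this too is a limit of the assay. Both values shown sit at that limit (the limit of > 6 h in this assay, at which 2 of the 2 values shown sit), so compound 2 has no exact half-life and cannot be ranked against compound 1. Compound 3 `C=CC(=O)N[C@@H]1CCCN(S(=O)(=O)c2ccc(NC(=O)OCc3ccccc3)cc2)C1` differs from compound 2 only in configuration: the two compounds have the same atoms and bonds and differ only in configuration as drawn: 1 of 1 stereo elements differ; a stereocentre at a saturated ring carbon is drawn S in compound 2 and R in compound 3. Among the measured compounds shown here, no measured pair yet shows what such a change does in this assay. The expectation therefore rests on compound 2 alone, with its limit of > 6 h. The expected step that the limit leaves unreadable from compound 2 to compound 3 is no change beyond the usual scatter, in either direction. The half-life of compound 3 is estimated at 8 h, with an expected range from 4 h to 16 h, and the assay will most likely report it as a limit again.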

Compound 3, half-life: > 6 h
Compound 3 was reported as a limit (the forecaster's own chance of this, stated with the estimate: 85%); the middle value is on the limit's open side.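

Compound 3 gives > 6 h in this assay, which is a limit of the assay and not a number. Among the compounds shown here, compound 2 also sits at a limit, so no step between compound 2 and compound 3 can be read: the limit of > 6 h in this assay, at which 3 of the 3 values shown sit. The compounds shown leave open whether configuration affects the half-life, and how long each compound actually lasts.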